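A few compounds are considered here, and "the series" means these few. Any claim that something is new, unique, unknown or untested is made for them only; others in the source may bear on it.

Measured in a functional assay on A549 cells (Homo sapiens) for antiproliferative activity, read by MTT assay, with a stated time of 48 h; on this read-out higher numbers stand for weaker inhibition and lower numbers for stronger inhibition:
- compound 1 `COc1ccc(N(C)c2ccnc(Cl)n2)cc1OCCCCBr`: 591 nM
- compound 2 `COc1ccc(N(C)c2ccnc(Cl)n2)cc1OCCCCCBr`: 9720 nM
- compound 3 `COc1ccc(N(C)c2ccnc(Cl)n2)cc1OCC[Se]C#N`: 463 nM

Compound 3 stands at 463 nM. The measured step of a 1.3-fold lower number from compound 1 to compound 3 (0.11 log units; within the scatter) does not separate it from the shorter bromide, while a 21-fold lower number from compound 2 to compound 3 (1.32 log units; beyond the scatter) sets it clearly apart from the longer one.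

The next compound to be tested is compound 4 `COc1ccc(N(C)c2ccnc(Cl)n2)cc1OCCC[Se]C#N`. It differs from compound 3 by a group of 4 heavy atoms (2 carbon, 1 nitrogen, 1 selenium; no ring) in place of a group of 3 heavy atoms (1 carbon, 1 nitrogen, 1 selenium; no ring), on a saturated chain carbon, two bonds along the chain from an oxygen on an aromatic ring, on a saturated chain carbon, two bonds along the chain from an oxygen on an aromatic ring. In effect, the chain grows while the selenium-bearing end stays the same.

Going by the values given here, the closest precedent is the bromide pair, where lengthening the chain gave a large loss: a 16-fold higher number from compound 1 to compound 2 (1.22 log units; beyond the scatter). That step belongs to a different end group and a different chain length, so it offers a direction more than a size. Among the compounds with values here, no pair with the selenium-bearing end at two chain lengths has been measured yet. The step expected in this assay is therefore toward a higher number, estimated as a 2.6-fold higher number from compound 3 to compound 4 (0.41 log units; beyond the scatter), smaller than the bromide jump but with wide uncertainty.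

For compound 4 the estimated value is 1200 nM, with an expected range of 350 nM to 5000 nM.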

Compound 4, half-maximal inhibitory concentration: 3710 nM
Compound 4: middle estimate off by 3.1-fold (0.49 log units), on the low side; the measured number falls inside the stated range.
By their numbers in this assay, from the lowest: compounds 3 and 1 (each within the scatter of the next); then compound 4; then compound 2.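

In this assay, the longer chain now costs activity with the selenium-bearing end as well: an 8.0-fold higher number from compound 3 to compound 4 (0.90 log units; beyond the scatter). This is the same direction as the bromide pair, a 16-fold higher number from compound 1 to compound 2 (1.22 log units; beyond the scatter), so within these two pairs the loss on lengthening the chain appears with both end groups. Going from the bromide to the selenium-bearing end at the longer chain gives a 2.6-fold lower number from compound 2 to compound 4 (0.42 log units; beyond the scatter), and the shift in the end group reads alike at both chain lengths: the same change on two cores in this assay, a 1.3-fold lower number (0.11 log units; within the scatter) from compound 1 to compound 3 and a 2.6-fold lower number (0.42 log units; beyond the scatter) from compound 2 to compound 4, 2.1-fold (0.31 log units) apart, within the scatter of two such steps Chain length and end group also change together in a 6.3-fold higher number from compound 1 to compound 4 (0.80 log units; beyond the scatter), which places the longer selenium-bearing compound clearly on the weaker side of the shorter bromide.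

The compounds shown leave open whether activity keeps falling with a still longer chain bearing the selenium-bearing end, since only two chain lengths are available for each end group. They also leave open whether the selenium atom itself matters, which a thiocyanate end with sulfur in place of selenium, or an amine at the chain end, would help to test on the shared core.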